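Series notes: amine substituent change, compound 2 to compound 4

The compounds below may be only part of what the source reports. "The series", "measured", "known", "first", "only" and "open" are said of these compounds alone.

Measured so far:
- Compound 1 `O[C@H]1Cc2ccccc2C1NC1CCN(CCCc2c[nH]c3ccc(-n4cnnc4)cc23)CC1`: 300 nM in an assay on CHO cells for displacement of a labelled ligand from 5-hydroxytryptamine receptor 1B (Homo sapiens); a lower number here means a stronger inhibitor, a higher number a weaker inhibitor
- Compound 2 `c1ccc(CNCC2CCN(CCCc3c[nH]c4ccc(-n5cnnc5)cc34)CC2)cc1`: 28 nM in this assay
- Compound 3 `CN(Cc1cccs1)C1CCN(CCCc2c[nH]c3ccc(-n4cnnc4)cc23)CC1`: 140 nM in this assay

Compound 2 gives the lowest number of the three; both an 11-fold lower number from compound 1 to compound 2 (1.03 log units; beyond the scatter) and a 5.0-fold higher number from compound 2 to compound 3 (0.70 log units; beyond the scatter) lie beyond the scatter. Compound 4 `CC(=O)Nc1ccc([C@@H](C)NCC2CCN(CCCc3c[nH]c4ccc(-n5cnnc5)cc34)CC2)cc1` differs from compound 2 by 1-(4-acetamidophenyl)ethyl in place of benzyl on an amine nitrogen. Among the compounds with values here, no measured step alters the substituent on that amine nitrogen alone: an 11-fold lower number from compound 1 to compound 2 (1.03 log units; beyond the scatter) and a 2.1-fold lower number from compound 1 to compound 3 (0.33 log units; beyond the scatter) each change the group on the saturated ring carbon, and a 5.0-fold higher number from compound 2 to compound 3 (0.70 log units; beyond the scatter) exchanges linker and aryl together, so they set the scale of the series without a direct precedent for this change. The expected step of a 1.6-fold higher number from compound 2 to compound 4 (0.21 log units; within the scatter) is therefore small, with a modest loss the more likely direction. Compound 4 is estimated at 45 nM, range 12 nM to 160 nM, in this assay.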

Compound 4, half-maximal inhibitory concentration: 8.9 nM
Compound 4: the middle estimate sits 5.1-fold (0.70 log units) above what was measured, and the stated range ends above it.
By their numbers in this assay, from the lowest: compound 4; then compound 2; then compound 3; then compound 1.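

Within the data shown here, the substituent on this amine nitrogen can grow without loss: 1-(4-acetamidophenyl)ethyl in place of benzyl gives a 3.1-fold lower number from compound 2 to compound 4 (0.50 log units; beyond the scatter) in this assay, the only measured step that alters this substituent alone. That single step brings in the acetamido group, a methyl branch and a defined stereocentre together, and cannot be divided among them. No measurement here bears on why the number falls.

From the compounds shown here alone, whether 1-phenylethyl alone, or the opposite configuration at the stereocentre, would keep the lower number stays open. So does the effect of a methanesulfonamide or a nitrile in place of the acetamido group.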